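A few compounds are considered here, and "the series" means these few. Any claim that something is new, unique, unknown or untested is made for them only; others in the source may bear on it.

Measured compounds:
- compound 1 `c1ccc2c(c1)CC(c1nc3ccc(-c4cn[nH]c4)cc3[nH]1)CO2` gives 86 nM in an assay on cells for inhibition of Rho-associated protein kinase 2 (Homo sapiens); on this read-out lower numbers stand for stronger inhibition and higher numbers for weaker inhibition
- compound 2 `CC(C)Oc1ccc2c(c1)CC(c1nc3ccc(-c4ccnc(N)n4)cc3[nH]1)CO2` gives "not determined" (no result reported) in this assay, that is, no result

Within the data shown here, compound 1 is the only member of the set with a number in this assay, and compound 1 gives 86 nM there. For compound 2 no result was reported, so compound 2 stands nowhere on the numbers shown: there is no single value to place it against compound 1, and no step between the two measured compounds is known.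

Compound 3 `Nc1nccc(-c2ccc3nc(C4COc5ccc(C(=O)NCc6ccccc6)cc5C4)[nH]c3c2)n1` differs from compound 2 in one place: benzylcarbamoyl in place of isopropoxy on an aromatic carbon. Since compound 2 has no value in this assay, the step from compound 2 to compound 3 cannot be sized from data; the account can only state an expectation. The expectation for compound 3 rests on the shared core of compound 1, which gives 86 nM, and on the fact that compound 3 keeps that core while carrying the benzylcarbamoyl group. Compound 3 is therefore expected to fall near compound 1, with a wide range to reflect the missing anchor in compound 2. Compound 3 is estimated at 50 nM, between 8 nM and 300 nM, in this assay.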

Compound 3, half-maximal inhibitory concentration: 23 nM
Compound 3: the middle estimate sits 2.2-fold (0.34 log units) above what was measured; the range from low to high includes it.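

No new step can be read from this result: compound 3 differs in one place only from compound 2, and compound 2 has no value in this assay to set against it. No evidence at hand bears on the result for compound 3. The compounds shown leave open how benzylcarbamoyl in place of isopropoxy changes inhibition.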